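The source may report more compounds than this note shows. Statements on the series, on what has been measured and on what is new or still open speak of the compounds shown alone.

Measured so far in a functional assay on OVCAR-4 cells (Homo sapiens) for inhibition, read by sulforhodamine B assay, with a stated time of 48 h; on this read-out lower numbers stand for stronger inhibition of growth and higher numbers for weaker inhibition of growth: compound 1 `O=C(Nc1cccc(-n2cc(-c3ccncc3)c(-c3ccc(Cl)c(O)c3)n2)c1)Nc1cccc(C(F)(F)F)c1` gives 3180 nM; compound 2 `COc1cc(-c2nn(-c3cccc(NC(=O)Nc4cccc(C(F)(F)F)c4)c3)cc2-c2ccncc2)ccc1Cl` gives 1100 nM; compound 3 `COc1cc(-c2nn(-c3cccc(NC(=O)c4ccc(Cl)c(C(F)(F)F)c4)c3)cc2-c2ccncc2)ccc1Cl` gives 8040 nM.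

Compound 3 shows the highest number of the three, that is the weakest inhibition of growth; compound 1 lies nearest to it and compound 2 furthest. Compound 4 `COc1cc(-c2nn(-c3cccc(NC(=O)c4ccccc4)c3)cc2-c2ccncc2)ccc1Cl` differs from compound 3 by phenyl in place of 4-chloro-3-(trifluoromethyl)phenyl on a carbonyl carbon. Going by the values given here, no measured step removes a chloro or trifluoromethyl group. The step of a 7.3-fold higher number from compound 2 to compound 3 (0.86 log units; beyond the scatter) changed the group on the same carbonyl carbon, but in another way, and a 2.9-fold lower number from compound 1 to compound 2 (0.46 log units; beyond the scatter) concerns a different place. With nothing that bears directly on this change, the expected step in this assay is a 1.0-fold lower number from compound 3 to compound 4 (0.00 log units; within the scatter), essentially none beyond the scatter. Compound 4 is therefore estimated at 8000 nM, within a range of 2500 nM to 25000 nM.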

Compound 4, concentration for 50% growth inhibition: 1170 nM
Beside the measured number, compound 4's estimate is 6.8-fold (0.83 log units) above it; measured number outside the range, below it.
By their numbers in this assay, from the lowest: compounds 2 and 4 (each within the scatter of the next); then compound 1; then compound 3.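

In this assay the 4-chloro-3-(trifluoromethyl)phenyl group on this carbonyl carbon is not required for growth inhibition: phenyl in its place gives a 6.9-fold lower number from compound 3 to compound 4 (0.84 log units; beyond the scatter) and so stronger inhibition. The step of a 1.1-fold higher number from compound 2 to compound 4 (0.03 log units; within the scatter) lies within the scatter, so phenyl and the (3-(trifluoromethyl)phenyl)amino group cannot be told apart at this position. Nothing shown explains these results. On these data alone, it remains open whether the chloro or the trifluoromethyl group alone accounts for the weaker inhibition, and how an amine or a carboxylic acid on this phenyl ring would behave.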